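A few compounds are considered here, and "the series" means these few. Any claim that something is new, unique, unknown or untested is made for them only; others in the source may bear on it.

Compound 3 `CC(=O)OCC(=O)OCCc1c(-c2ccccc2Cl)c2cc(Cl)ccc2[nH]c1=O` stands second highest of the three numbers measured in an ADME assay on HepG2 2.2.15 cells (Homo sapiens) for cytotoxicity (on this read-out higher numbers stand for lower toxicity in this test and lower numbers for higher toxicity in this test), where compound 3 gives 100000 nM. Compound 2 `CCOCC(=O)OCCc1c(-c2ccccc2Cl)c2cc(Cl)ccc2[nH]c1=O` sits nearest, giving 130000 nM. Compound 1 `C=CCn1c(=O)c(CCO)c(-c2ccccc2Cl)c2cc(Cl)ccc21` differs from compound 3 in several places; in this assay compound 1 gives 23000 nM, the lowest number of the three. Compound 4 `O=C(/C=C/c1cccc(F)c1)OCCc1c(-c2ccccc2Cl)c2cc(Cl)ccc2[nH]c1=O` differs from compound 3 in one place.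

2-(3-fluorophenyl)ethenyl in place of acetoxymethyl on a carbonyl carbon

Among the compounds with values here, only one measured step touches the same part of the molecule, the ester tail, and it was a 1.3-fold lower number from compound 2 to compound 3 (0.11 log units; within the scatter), a small swap that left the number essentially unchanged. Within the data shown here, no measured step adds anything as large as a 2-(3-fluorophenyl)ethenyl group, so the evidence for compound 4 is thin. On that basis a modest move toward a lower number, with wide uncertainty, is expected for compound 4, amounting to an estimated step of a 1.7-fold lower number from compound 3 to compound 4 (0.22 log units; within the scatter). Compound 4 is therefore estimated at 60000 nM in this assay, with a likely range from 20000 nM to 150000 nM.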

Compound 4, half-maximal cytotoxic concentration: > 1600000 nM
Compound 4: no number, only a limit (the forecaster's own chance of this, stated with the estimate: 10%); middle value at least 26-fold (1.42 log units) away from the limit.
By their numbers in this assay, from the lowest: compound 1; then compounds 3 and 2 (each within the scatter of the next). At a limit, above all of these: compound 4.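

In this assay the group on this carbonyl carbon turns out to matter a great deal: 2-(3-fluorophenyl)ethenyl in place of acetoxymethyl gives an at least 16-fold higher number from compound 3 to compound 4 (1.20 log units; beyond the scatter) and the same group in place of ethoxymethyl gives an at least 12-fold higher number from compound 2 to compound 4 (1.09 log units; beyond the scatter) in the same direction. Within the data shown here, the only earlier step at this place was a 1.3-fold lower number from compound 2 to compound 3 (0.11 log units; within the scatter) and gave no sign that the read-out could move this far toward lower toxicity in this test. Compound 4 has no exact number, only a limit of the assay: the limit of > 1600000 nM in this assay, at which 1 of the 4 values shown sits.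

From the compounds shown here alone, the full size of the step therefore stays open, as does whether the aromatic ring, the fluorine or the ethenyl link carries it. The compounds shown also leave open how an amine or a carboxylic acid on this carbonyl carbon would read.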